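Isopropyl for phenyl on the ring amide nitrogen

The source may report more compounds than this note shows. Statements on the series, on what has been measured and on what is new or still open speak of the compounds shown alone.

Three compounds built on a shared core have been examined in a functional assay on HepG2 cells (Homo sapiens) for antiproliferative activity, read by MTT assay, with a stated time of 72 h; on this read-out lower numbers stand for stronger inhibition and higher numbers for weaker inhibition. For compound 1 `COc1ccc(N2C(=O)COc3ccc(-c4cnc5ccccc5c4)cc32)cc1` the read-out is > 40000 nM, which is a limit of the assay, so no number is known for it. That read-out sits at the limit of > 40000 nM in this assay, at which 1 of the 3 values shown sits. Compound 3 `COc1ccc(N2C(=O)COc3ccc(-c4ccc(O)cc4)cc32)cc1` gives 10800 nM in this assay. Compound 2 `O=C1COc2ccc(-c3cnc(Cl)c(NS(=O)(=O)c4ccc(F)cc4)c3)cc2N1c1ccccc1` gives 35700 nM in this assay, the higher of the two numbers available, and its gap to compound 3 lies beyond the usual scatter of repeated measurements. Within the data shown here, no two measured compounds differ in a single place, so no measured step exists to guide the next change.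

Compound 4 `CC(C)N1C(=O)COc2ccc(-c3cnc(Cl)c(NS(=O)(=O)c4ccc(F)cc4)c3)cc21` is derived from compound 2 by a single change: isopropyl in place of phenyl on an amide-type nitrogen in a ring. Nothing among the three measured compounds speaks to what this particular exchange does in this assay. He therefore expects the step from compound 2 to compound 4 to be small, of a size estimated at a 1.0-fold lower number from compound 2 to compound 4 (0.01 log units; within the scatter), with no clear direction beyond the scatter. His estimate for compound 4 in this assay is 35000 nM, within a range expected to run from 10000 nM to 100000 nM, and he notes a real chance that the assay returns only a limit for compound 4.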

Compound 4, half-maximal inhibitory concentration: 21500 nM
Compound 4: middle estimate off by 1.6-fold (0.21 log units), on the high side; the range from low to high includes it.
By their numbers in this assay, from the lowest: compounds 3, 4 and 2 (each within the scatter of the next, the first and the last beyond it). At a limit, above all of these: compound 1.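

In this assay, among these compounds, putting isopropyl in place of phenyl on the amide-type nitrogen in a ring gives a 1.7-fold lower number from compound 2 to compound 4 (0.22 log units; within the scatter), the first step that can be read at this position. At this position, then, a group with no ring and only 3 heavy atoms serves as well as the phenyl with its six-membered aromatic ring: the two values cannot be told apart in this assay, so the aromatic ring shows no measurable contribution to the read-out in this pair. Nothing in the available evidence bears on why the exchange leaves the number within the scatter, and no explanation can be drawn from it.

The compounds shown leave open whether any group at this nitrogen can move the number beyond the scatter, for instance a longer chain, a chain ending in an amine, or a carboxylic acid. Among the compounds shown here, they also leave open whether the exchange of phenyl for isopropyl would give a similar step with other groups elsewhere on the shared core, since this single pair is the only step available.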